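From a methoxymethylbenzyl amide to a chlorobenzyl amide

The source may hold more compounds than are shown below. What is called first, only, known or untested is meant among the compounds shown, and "the series" means these compounds.

Three compounds share one core and differ only in the group carried on the amide nitrogen. Compound 1 `CCN(Cc1ccccc1)C(=O)c1nn(-c2ccc(F)cc2)c(OC[C@@H](O)C[C@@H](O)CC(=O)O)c1C(C)C` gives 14 nM in an assay on microsomes from liver for inhibition of 3-hydroxy-3-methylglutaryl-coenzyme A reductase (Rattus norvegicus); on this read-out higher numbers stand for weaker inhibition and lower numbers for stronger inhibition. Compound 2 `Cc1ccccc1CNC(=O)c1nn(-c2ccc(F)cc2)c(OC[C@@H](O)C[C@@H](O)CC(=O)O)c1C(C)C` gives 17 nM in this assay, and compound 3 `COCc1cccc(CNC(=O)c2nn(-c3ccc(F)cc3)c(OC[C@@H](O)C[C@@H](O)CC(=O)O)c2C(C)C)c1` gives 31 nM. Compound 3 thus stands at the highest number of the three: the step of a 1.8-fold higher number from compound 2 to compound 3 (0.26 log units; within the scatter) stays within the scatter, while a 2.2-fold higher number from compound 1 to compound 3 (0.35 log units; beyond the scatter) is modest but beyond it.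

Compound 4 `CC(C)c1c(C(=O)NCc2ccc(Cl)cc2)nn(-c2ccc(F)cc2)c1OC[C@@H](O)C[C@@H](O)CC(=O)O` differs from compound 3 by 4-chlorophenyl in place of 3-(methoxymethyl)phenyl on a saturated chain carbon bound to an amide-type nitrogen. Among the measured compounds shown here, no measured step brings in a chlorine substituent, so the direct bearing of the data is limited. For the measured compounds named here, the one step on the same aromatic ring, a 1.8-fold higher number from compound 2 to compound 3 (0.26 log units; within the scatter), was within the scatter, and the larger change a 2.2-fold higher number from compound 1 to compound 3 (0.35 log units; beyond the scatter) was only modest. Because compound 3 sits at the high end with 31 nM, the expected step for compound 4 is a 1.6-fold lower number from compound 3 to compound 4 (0.19 log units; within the scatter), small and toward a lower number, if any beyond the scatter. Compound 4 is estimated at 20 nM, with a range from 8 nM to 50 nM.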

Compound 4, half-maximal inhibitory concentration: 6.7 nM
Compound 4: the middle estimate sits 3.0-fold (0.47 log units) above what was measured; the whole stated range lies above it.
By their numbers in this assay, from the lowest: compound 4; then compounds 1, 2 and 3 (each within the scatter of the next, the first and the last beyond it).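

Compound 4 shows that this place, on a saturated chain carbon bound to an amide-type nitrogen, can also move the number down in this assay, with a step beyond the scatter against each earlier compound: (a 4.6-fold lower number from compound 3 to compound 4 (0.67 log units; beyond the scatter)), (a 2.5-fold lower number from compound 2 to compound 4 (0.40 log units; beyond the scatter)) and (a 2.1-fold lower number from compound 1 to compound 4 (0.32 log units; beyond the scatter)). Compound 2 and compound 3 had stayed within the scatter of each other, so only the 4-chlorophenyl separates an aryl change at this carbon from that scatter, and compound 4 is the strongest inhibitor of the four. Nothing shown accounts for this step.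

The compounds shown leave open whether the chlorine itself is needed, which a 4-methylphenyl or a 4-bromophenyl at this carbon would test. They also leave open what an ethyl on the amide nitrogen of compound 4 would do.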